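This account rests on a few compounds, and the source may have more. Where it says the series, first, only, none or still open, it means among the compounds named here.

Working notes on the series in an ADME assay on HEK293 cells (Homo sapiens) for cytotoxicity, read by ATP content, with a stated time of 6 h; on this read-out higher numbers stand for lower toxicity in this test and lower numbers for higher toxicity in this test. Compound 1, `CCCCNc1nc(N)nc2ccn(CCCc3ccccc3)c12`, sits at the assay limit: in this assay compound 1 gives > 24000 nM, which is a limit rather than a number. Compound 2, `COCCCNc1nc(N)nc2ccn(Cc3ccccn3)c12`, reads the same way: in this assay compound 2 gives > 24000 nM, again a limit and not a number. Among the compounds with values here, both values therefore rest at the limit of > 24000 nM in this assay, at which 2 of the 2 values shown sit, so no step between measured compounds can be stated, and compound 2 stands at the same limit as compound 1. Compound 3, `Cc1cc(CNc2nc(N)nc3ccn(Cc4ccccn4)c23)on1`, is still to be measured in this assay. The change from compound 2 is 3-methyl-1,2-oxazol-5-yl in place of 2-methoxyethyl on a saturated chain carbon bound to a nitrogen on an aromatic ring. With both shown values at the limit, the expected step that the limit leaves unreadable from compound 2 to compound 3 is none beyond the scatter, and compound 3 is expected most likely to return a limit as well. The estimate for compound 3 in this assay is 30000 nM, with a range from 15000 nM to 80000 nM.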

Compound 3, half-maximal cytotoxic concentration: > 24000 nM
Compound 3 ended at the assay's limit (the forecaster's own chance of this, stated with the estimate: 80%); the middle value does not contradict the limit.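

Compound 2 and compound 3 give no readable step in this assay, as both values are limits and not numbers: the limit of > 24000 nM in this assay, at which 3 of the 3 values shown sit. The compounds shown leave open how far past this limit each half-maximal cytotoxic concentration lies, and whether exchanging these groups changes it at all.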